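Benzyloxy in place of methoxy on a flavone piperazine amide

The compounds below may be only part of what the source reports. "The series", "measured", "known", "first", "only" and "open" are said of these compounds alone.

Measured so far:
compound 1 `CCOC(=O)COc1cc(-c2cc(=O)c3c(O)cc(OCC(=O)N4CCN(Cc5ccc(OC)c(OC)c5OC)CC4)cc3o2)ccc1OC` — > 70000 nM
compound 2 `CCOC(=O)COc1cc(-c2cc(=O)c3c(O)cc(OCC(=O)N4CCN(Cc5ccc(OC)cc5)CC4)cc3o2)ccc1OC` — "not determined" (no result reported)

The series shares a flavone core carrying an ethyl ester side chain and a piperazine amide that ends in a substituted benzyl group. Compound 1 `CCOC(=O)COc1cc(-c2cc(=O)c3c(O)cc(OCC(=O)N4CCN(Cc5ccc(OC)c(OC)c5OC)CC4)cc3o2)ccc1OC` was tested in an ADME assay on MRC5 cells (Homo sapiens) for cytotoxicity (a lower number here means a stronger inhibitor, a higher number a weaker inhibitor), and gave > 70000 nM, which is a limit of the assay rather than a number. Compound 1 therefore stands at the limit of > 70000 nM in this assay, at which 1 of the 2 values shown sits. Compound 2 `CCOC(=O)COc1cc(-c2cc(=O)c3c(O)cc(OCC(=O)N4CCN(Cc5ccc(OC)cc5)CC4)cc3o2)ccc1OC` carries a single methoxy on its benzyl group, and in this assay compound 2 is recorded as "not determined" (no result reported), so it adds nothing on the scale.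

Compound 3 `CCOC(=O)COc1cc(-c2cc(=O)c3c(O)cc(OCC(=O)N4CCN(Cc5ccc(OCc6ccccc6)c(OC)c5OC)CC4)cc3o2)ccc1OC` differs from compound 1 in one place: phenyl in place of hydrogen on a saturated chain carbon bound to an oxygen on an aromatic ring, which reads methoxy to benzyloxy. Going by the values given here, no step between two measured compounds exists here, so the size of the change is not known from data. With compound 1 sitting only at a limit, compound 3 is expected to remain a weak inhibitor in this assay, the step from compound 1 to compound 3 being estimated as an at least 1.1-fold lower number from compound 1 to compound 3 (0.06 log units; that floor lies within the scatter). Compound 3 is thus expected to show about 60000 nM in this assay, within a range from 15000 nM to 200000 nM.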

Compound 3, half-maximal inhibitory concentration: 10000 nM
Compound 3: the middle estimate sits 6.0-fold (0.78 log units) above what was measured, outside the stated range (below it).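

In this assay, putting phenyl in place of hydrogen on a saturated chain carbon bound to an oxygen on an aromatic ring gives an at least 7.0-fold lower number from compound 1 to compound 3 (0.84 log units; beyond the scatter). This shows that the read-out responds to a change at this position, from methoxy to benzyloxy, which no earlier value could show. The value of compound 1 is a limit of the assay, so the step has a known floor but no known full size: the limit of > 70000 nM in this assay, at which 1 of the 3 values shown sits.

What the compounds shown leave open is whether the aromatic ring of the benzyl group is needed for this lower number, or whether an ethyl or cyclohexylmethyl group in place of the methyl would give a similar result. As far as these compounds go, it also remains open whether the same change from methoxy to benzyloxy would give a step of similar size on the other substituted benzyl groups of the series, and how a more distant replacement, such as a chain ending in an amine or a carboxylic acid, would read in this assay.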